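Quinazoline-linked series: replacing the acetoxymethyl substituent

This account rests on a few compounds, and the source may have more. Where it says the series, first, only, none or still open, it means among the compounds named here.

Measured so far:
compound 1 `COc1ccc2c(c1)NC(=O)CN2c1nc(COC(C)=O)nc2ccccc12` — 5.05 nM
compound 2 `COc1ccc2c(c1)NC(=O)CN2c1nc(OCC2CC2)nc2ccccc12` — 14.2 nM
compound 3 `COc1ccc2c(c1)NC(=O)CN2c1nc(Nc2cccc(C#N)c2)nc2ccccc12` — 61.5 nM

All three were run in a functional assay on KB cells (Homo sapiens) for inhibition, read by sulforhodamine B assay, with a stated time of 48 h; a lower number here means a stronger inhibitor of growth, a higher number a weaker inhibitor of growth. Compound 1 holds the lowest number of the three, with compound 2 the nearest to it and compound 3 the furthest away, both steps beyond the scatter.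

The unmeasured compound 4 `COc1ccc2c(c1)NC(=O)CN2c1nc(NC2CC2)nc2ccccc12` shares the core of compound 1 and differs from it in one place: cyclopropylamino in place of acetoxymethyl on an aromatic carbon

Among the measured compounds shown here, two measured steps bear on this change. Swapping acetoxymethyl for cyclopropylmethoxy gave a 2.8-fold higher number from compound 1 to compound 2 (0.45 log units; beyond the scatter), and swapping it for (3-cyanophenyl)amino gave a 12-fold higher number from compound 1 to compound 3 (1.09 log units; beyond the scatter). The new group, cyclopropylamino, carries the three-membered ring of compound 2 and the attached nitrogen with its hydrogen-bond donor of compound 3, but none of the aryl nitrile of compound 3. Both replacements of acetoxymethyl so far have raised the number, one modestly and one by a large amount, so a rise beyond the scatter is expected for compound 4 as well, more likely near the modest end.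

For compound 4 the estimate in this assay is 18 nM, within 6 nM to 55 nM, which corresponds to an expected step of a 3.6-fold higher number from compound 1 to compound 4 (0.55 log units; beyond the scatter).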

Compound 4, concentration for 50% growth inhibition: 2.11 nM
For compound 4 the middle estimate is 8.5-fold (0.93 log units) above the measured one, outside the stated range (below it).
By their numbers in this assay, from the lowest: compound 4; then compound 1; then compound 2; then compound 3.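

In this assay the aromatic carbon between two ring nitrogen atoms turns out to tolerate loss of acetoxymethyl without a rise, since cyclopropylamino gives a 2.4-fold lower number from compound 1 to compound 4 (0.38 log units; beyond the scatter) and is the only replacement among these compounds that moves the number downward. The three-membered ring alone does not account for this, as cyclopropylamino in place of cyclopropylmethoxy gives a 6.7-fold lower number from compound 2 to compound 4 (0.83 log units; beyond the scatter) and compound 2 carries that ring too; the attached nitrogen alone does not account for it either, as cyclopropyl in place of 3-cyanophenyl on that nitrogen gives a 29-fold lower number from compound 3 to compound 4 (1.46 log units; beyond the scatter) and compound 3 carries that nitrogen too. Within these four compounds, then, the low number belongs to the combination of nitrogen and cyclopropyl, although nothing available explains the differences between them.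

Open, on these data alone, is whether other small amines at this carbon, such as methylamino, cyclobutylamino or dimethylamino, the last without the amine hydrogen, hold the number as low as cyclopropylamino does. Also open, as far as these compounds go, is how far the number moves with a plain amino group or a methyl group at the same carbon, which would give simpler reference points for the series.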